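The compounds below may be only part of what the source reports. "The series", "measured", "known", "first", "only" and "open" are said of these compounds alone.

In a functional assay on ECa-109 cells (Homo sapiens) for antiproliferative activity, read by MTT assay, with a stated time of 72 h (a higher number here means a weaker inhibitor, a lower number a stronger inhibitor), the measured compounds are:

- compound 1 `CCCSc1nc(N/N=C/c2ccccc2Cl)c2nnn(Cc3ccccc3)c2n1`: 6180 nM
- compound 2 `C#CCSc1nc(N/N=C(\C)c2ccccc2O)c2nnn(Cc3ccccc3)c2n1`: 5250 nM
- compound 3 `C#CCSc1nc(N/N=C/c2cc(OC)c(OC)c(OC)c2)c2nnn(Cc3ccccc3)c2n1`: 6540 nM

Compound 1 holds the second highest of the three numbers in this assay. Its nearest neighbour is compound 3, whose number is slightly higher, and its furthest is compound 2, whose number is slightly lower; both gaps lie within the usual scatter, so the three compounds cannot be told apart on these data.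

Compound 4 `CCCSc1nc(N/N=C/c2c[nH]c3ccccc23)c2nnn(Cc3ccccc3)c2n1` is the next member and has not been measured in this assay. Against compound 1 the change is 1H-indol-3-yl in place of 2-chlorophenyl on a carbon with a double bond to nitrogen; the shared core and the propylsulfanyl and benzyl groups stay as they are.

Within the data shown here, no measured pair shows a change of this kind, so there is no step to lean on. Since the three different aryl groups of compound 1, compound 2 and compound 3 all land within the scatter of one another, the expectation for compound 4 is a step of no more than the scatter in this assay, in no set direction, a 1.1-fold lower number from compound 1 to compound 4 (0.05 log units; within the scatter). Compound 4 is thus estimated at 5500 nM, with a range from 2000 nM to 15000 nM.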

Compound 4, half-maximal inhibitory concentration: 8690 nM
Beside the measured number, compound 4's estimate is 1.6-fold (0.20 log units) below it; the range from low to high includes it.
By their numbers in this assay, from the lowest: compounds 2, 1, 3 and 4 (each within the scatter of the next).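

In this assay, among these compounds, 1H-indol-3-yl in place of 2-chlorophenyl on a carbon with a double bond to nitrogen gives a 1.4-fold higher number from compound 1 to compound 4 (0.15 log units; within the scatter), the first step that can be read at one place alone. This place therefore accepts a group with two aromatic rings and one hydrogen-bond donor in exchange for a group with one aromatic ring and no donor, with no change that can be told from the scatter. No measurement on hand bears on why the step has this size.

Whether any group at this place can move the number beyond the scatter stays open, as all the groups shown there are aromatic, and a longer chain, an amine or a carboxylic acid could behave differently. The propylsulfanyl group also remains unresolved, since no pair shown isolates it.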